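A few compounds are considered here, and "the series" means these few. Any claim that something is new, unique, unknown or untested is made for them only; others in the source may bear on it.

Compound 1 `COc1c(Br)cc(Br)cc1C(=O)Nc1ccc(Sc2nc3ccccc3s2)c(Cl)c1` gives in an assay on isolated protein for inhibition of thiosulfate sulfurtransferase (Homo sapiens), with a stated time of 60 min, in the absence of a further agent (a higher number here means a weaker inhibitor, a lower number a stronger inhibitor), a value of > 100000 nM, which is a limit of the assay and not a number.
Compound 2 `O=C(Nc1ccc(Sc2nc3ccccc3s2)c(Cl)c1)c1cc(Br)cc(Br)c1O` gives in this assay a value of > 100000 nM, again a limit and not a number.
Compound 3 `O=C(Nc1ccc(Sc2nc3ccccc3s2)cc1)c1cc(Br)cc(Br)c1O` gives in this assay a value of > 100000 nM, likewise a limit and not a number.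

On the numbers shown, compound 2 therefore stands only at a limit, and the two other values are limits as well (the limit of > 100000 nM in this assay, at which 3 of the 3 values shown sit). The step that the two limits leave unreadable from compound 1 to compound 2 cannot be read, and the same holds for a step that the two limits leave unreadable from compound 2 to compound 3; both concern parts of the molecule other than the ring on the carbonyl carbon.

Compound 4 `O=C(Nc1ccc(Sc2nc3ccccc3s2)c(Cl)c1)c1ccccc1` differs from compound 2 in that ring: phenyl in place of 3,5-dibromo-2-hydroxyphenyl on a carbonyl carbon. Among the compounds with values here, no measured step bears on this change, and since every measured value is a limit, no direction or size can be drawn from them. The expectation for compound 4 in this assay is therefore no readable change, and the step that the limit leaves unreadable from compound 2 to compound 4 is simply an estimate of staying at the limit. Compound 4 is expected at 200000 nM, with a range from 100000 nM to 1000000 nM.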

Compound 4, half-maximal inhibitory concentration: > 100000 nM
Compound 4 ended at the assay's limit; the forecaster's own chance of this, stated with the estimate: 90%; the middle value is on the limit's open side.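

In this assay compound 4 also stands only at a limit, so its steps from compound 1 and from compound 2 cannot be read: the limit of > 100000 nM in this assay, at which 4 of the 4 values shown sit.
The compounds shown leave open which change to the shared core, if any, would bring a measurable inhibition.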